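A few compounds are considered here, and "the series" means these few. Any claim that something is new, unique, unknown or untested is made for them only; others in the source may bear on it.

Measured in a functional assay on SK-OV-3 cells (Homo sapiens) for inhibition, read by ELISA, with a stated time of 24 h; on this read-out higher numbers stand for weaker inhibition of growth and lower numbers for stronger inhibition of growth:
compound 1 `O=C(Cl)/C=C/c1ccccc1OC(=O)c1ccccc1`: > 100000 nM (a limit)
compound 2 `CO/N=C/C=C/c1ccccc1OC(=O)c1ccccc1`: > 100000 nM (a limit)
compound 3 `O=C(/C=C/c1ccccc1O)NO`: 50400 nM

Compound 1 has no number in this assay, only a limit. It shares that position with compound 2, as the record shows: the limit of > 100000 nM in this assay, at which 2 of the 3 values shown sit. Going by the values given here, compound 3 is the only one with a number, 50400 nM.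

The step of interest leads to compound 4 `CN1CCN(C(=O)/C=C/c2ccccc2OC(=O)c2ccccc2)CC1`, and the structural change is 4-methylpiperazin-1-yl in place of chloro on a carbonyl carbon. Among the compounds with values here, the one measured step that replaces the group at this end of compound 1, a step that the two limits leave unreadable from compound 1 to compound 2, gives no size to carry over. No direction can therefore be read from it, and compound 4 is expected to remain near the limit of this assay, possibly without a number of its own. The expected step is an at least 1.4-fold lower number from compound 1 to compound 4 (0.15 log units; that floor lies within the scatter). For compound 4 the estimated value is 70000 nM, with an expected range of 20000 nM to 200000 nM.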

Compound 4, concentration for 50% growth inhibition: > 100000 nM
Compound 4 gave a limit, no number (the forecaster's own chance of this, stated with the estimate: 55%); middle value at least 1.4-fold (0.15 log units) away from the limit.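

In this assay compound 4 gives > 100000 nM as a limit and not a number. Compound 1 also has only a limit, so no step can be read between compound 1 and compound 4. The compounds shown leave open how large the effect of 4-methylpiperazin-1-yl in place of chloro is on growth inhibition.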